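Metabolic stability in the series: compound 4 next

The compounds below may be only part of what the source reports. "The series", "measured", "known", "first", "only" and "open" are said of these compounds alone.

Measured so far:
compound 1 `COc1ccc(C2=Nc3c(C(C)(C)C)nn(CCCO)c3C(=O)NC2)cc1-c1ccccc1F` 0.8 h
compound 2 `COc1ccc(C2=Nc3c(C(C)(C)C)nn(CCCO)c3C(=O)NC2)cc1-c1ccccc1SC` 0.85 h
compound 3 `COc1ccc(-c2cc(C3=Nc4c(C(C)(C)C)nn(CCCO)c4C(=O)NC3)ccc2OC)cn1` 2 h

In an ADME assay on microsomes from liver (Homo sapiens) for metabolic stability (on this read-out higher numbers stand for a longer-lived compound and lower numbers for a shorter-lived compound), compound 1 sits at the bottom of the three numbers, though its nearest neighbour is compound 2 at 0.85 h, and the step of a 1.1-fold higher number from compound 1 to compound 2 (0.03 log units; within the scatter) lies within the scatter. Compound 3 stands apart from both: a 2.5-fold higher number from compound 1 to compound 3 (0.40 log units; beyond the scatter) and a 2.4-fold higher number from compound 2 to compound 3 (0.37 log units; beyond the scatter) are each beyond the scatter, modest upward steps.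

Compound 4 `COc1ccc(C2=Nc3c(C(C)(C)C)nn(CCCO)c3C(=O)NC2)cc1-c1cnc(N(C)C)cc1C` has not yet been measured in this assay. Relative to compound 1 the change is 6-(dimethylamino)-4-methylpyridin-3-yl in place of 2-fluorophenyl on an aromatic carbon. For the measured compounds named here, the one measured step that bears on it is the one from compound 1 to compound 3, a 2.5-fold higher number from compound 1 to compound 3 (0.40 log units; beyond the scatter), where a pyridinyl also replaced 2-fluorophenyl at the same aromatic carbon, ortho to a methoxy group and meta to a large group. Going by the values given here, the entering group here carries dimethylamino and methyl rather than methoxy, so the analogy is loose, and no measured pair tests those substituents.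

On that basis a modest upward step a 1.6-fold higher number from compound 1 to compound 4 (0.21 log units; within the scatter) is expected for compound 4, and its half-life in this assay is estimated at 1.3 h, with a range of 0.6 h to 2.8 h.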

Compound 4, half-life: 0.7 h
Compound 4: the middle estimate sits 1.9-fold (0.27 log units) above what was measured, and the stated range covers the measured number.
By their numbers in this assay, from the lowest: compounds 4, 1 and 2 (each within the scatter of the next); then compound 3.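

In this assay, a pyridinyl group at this aromatic carbon, ortho to a methoxy group, does not by itself bring the higher number: with 6-(dimethylamino)-4-methylpyridin-3-yl in place, the reading is a 1.1-fold lower number from compound 1 to compound 4 (0.06 log units; within the scatter) and a 1.2-fold lower number from compound 2 to compound 4 (0.08 log units; within the scatter), so this group cannot be told apart from 2-fluorophenyl or 2-(methylsulfanyl)phenyl. Against 6-methoxypyridin-3-yl the same group gives a 2.9-fold lower number from compound 3 to compound 4 (0.46 log units; beyond the scatter), which ties the earlier gain to that particular substituted pyridinyl and not to the pyridinyl ring as a class. Nothing available explains the difference between these two pyridinyl groups.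

Going by these compounds, the two groups differ in both the methoxy versus dimethylamino substituent and the added methyl, so it remains open which of these changes goes with the lower number; 6-(dimethylamino)pyridin-3-yl and 6-methoxy-4-methylpyridin-3-yl would separate them. Also open, on these data alone, is how an unsubstituted pyridin-3-yl or a 6-(morpholin-4-yl)pyridin-3-yl would read at this position.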